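The source may report more compounds than this note shows. Statements on the series, on what has been measured and on what is new or still open speak of the compounds shown alone.

Compound 1 `O=[N+]([O-])c1cccc(-c2ccc(O[C@H]3O[C@H](CO)[C@@H](O)[C@H](O)[C@@H]3O)c(Cl)c2)c1` gives 23 ug/mL in a physicochemical assay for solubility, measured as kinetic solubility, with a stated time of 15 h, at pH 7.4; on this read-out lower numbers stand for lower solubility and higher numbers for higher solubility; compound 2 `CC(=O)c1ccc(-c2ccc(O[C@H]3O[C@H](CO)[C@@H](O)[C@H](O)[C@@H]3O)c(Cl)c2)cc1` gives 16 ug/mL in this assay, the lower of the two numbers shown, though the pair lies within the scatter: a 1.4-fold lower number from compound 1 to compound 2 (0.16 log units; within the scatter). Compound 3 `OC[C@H]1O[C@H](Oc2ccc(-c3ccc(Cl)cc3)cc2Cl)[C@@H](O)[C@@H](O)[C@@H]1O` follows from compound 2 by chloro in place of acetyl on an aromatic carbon. Within the data shown here, no measured step covers this change; the single step from compound 1 to compound 2 swaps one substituted phenyl for another and is within the scatter, so it offers no direct guide. Loss of the acetyl acceptor is expected to move compound 3 down, estimated as a 2.3-fold lower number from compound 2 to compound 3 (0.36 log units; beyond the scatter). Compound 3 is estimated at 7 ug/mL, range 2.5 ug/mL to 20 ug/mL.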

Compound 3, solubility: 3.5 ug/mL
The estimate for compound 3 lay 2.0-fold (0.30 log units) above the measured number, and the stated range covers the measured number.
By their numbers in this assay, from the lowest: compound 3; then compounds 2 and 1 (each within the scatter of the next).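

In this assay, this aromatic carbon now shows a change beyond the scatter: chloro in place of acetyl gives a 4.6-fold lower number from compound 2 to compound 3 (0.66 log units; beyond the scatter), and 4-chlorophenyl in place of 3-nitrophenyl gives a 6.6-fold lower number from compound 1 to compound 3 (0.82 log units; beyond the scatter), leaving compound 3 lowest of the three. The substituted phenyl group can therefore move this read-out, which the earlier step within the scatter did not show. Nothing measured here bears on the reason for the drop. On these data alone, whether an amine or a carboxylic acid at this place would raise the number remains open. So does whether a methyl group would track chloro or acetyl.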